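The source may hold more compounds than are shown below. What is called first, only, known or untested is meant among the compounds shown, and "the series" means these compounds.

Working notes on the thienylmethyl amide series. Of the compounds shown here, two have numbers so far. Compound 1 `CCN(Cc1cccs1)C(=O)c1cc2cc(C)ccc2o1` carries an ethyl on the amide nitrogen together with a fused bicyclic core; in an assay on HEK293 cells for agonist activity at transient receptor potential cation channel subfamily M member 8 (Homo sapiens), read by fluorescence and calcium flux, with a stated time of 15 min (on this read-out higher numbers stand for an effect only at larger amounts of compound and lower numbers for an effect already at smaller amounts), compound 1 gives 120 nM. Compound 2 `Cc1ccc(OCC(=O)N(CCO)Cc2cccs2)cc1` keeps the thienylmethyl on the amide nitrogen but pairs it with a 2-hydroxyethyl and an aryloxyacetyl carbonyl side; in this assay compound 2 gives 900 nM. Compound 2 thus stands at the highest of the two numbers, and its gap to compound 1 lies beyond the scatter of the measurement. Among the measured compounds shown here, no single-point step between the two measured compounds can be drawn, since they differ in more than one place.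

Compound 3 `Cc1ccc(OCC(=O)N(Cc2cccs2)c2cn[nH]c2)cc1` is the next candidate. It differs from compound 2 in one place: 1H-pyrazol-4-yl in place of 2-hydroxyethyl on an amide-type nitrogen. Nothing measured in this set speaks to what an aryl group on this nitrogen does, so the expectation rests on compound 2 alone. The step from compound 2 to compound 3 is expected to be a 1.7-fold higher number from compound 2 to compound 3 (0.22 log units; within the scatter), that is, no change beyond the scatter, with a slight lean toward a higher number. For compound 3 the estimated value is 1500 nM, with a plausible range from 400 nM to 6000 nM.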

Compound 3, half-maximal effective concentration: 1.4 nM
Compound 3: middle estimate off by 1100-fold (3.03 log units), on the high side; measured number below the stated range.
By their numbers in this assay, from the lowest: compound 3; then compound 1; then compound 2.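

Among the compounds shown here, the amide-type nitrogen proves to be a highly sensitive position in this assay: 1H-pyrazol-4-yl in place of 2-hydroxyethyl gives a 640-fold lower number from compound 2 to compound 3 (2.81 log units; beyond the scatter), the first one-place step and a large one. The two groups have the same counts of hydrogen-bond donors and acceptors and neither carries a net charge, so these counts do not separate them; what does differ is the five-membered aromatic ring with its 2 hetero atoms and the rise from 3 to 5 heavy atoms. No measurement in hand accounts for the step or assigns it to any one of these differences.

The compounds shown leave open whether the step depends on the ring nitrogens or on the aromatic ring alone, a question that a phenyl or a 1-methyl-1H-pyrazol-4-yl on the same nitrogen would address. Also open, as far as these compounds go, is whether 1H-pyrazol-4-yl in place of the ethyl of compound 1 gives a step of similar size on the core of compound 1.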